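The source may report more compounds than this note shows. Statements on the series, on what has been measured and on what is new or still open speak of the compounds shown alone.

Measured so far:
compound 1 `O=C(Nc1cc(-c2ccccc2)nn1-c1ccccc1Cl)c1ccccc1` — 62 nM
compound 2 `O=C(Nc1cc(-c2ccccc2)nn1-c1cccc(Br)c1)c1ccccc1` — 400 nM

Within the data shown here, in a functional assay on cells for positive allosteric modulation of metabotropic glutamate receptor 5 (Rattus norvegicus), read by calcium flux (on this read-out higher numbers stand for an effect only at larger amounts of compound and lower numbers for an effect already at smaller amounts), compound 1 gives 62 nM, and compound 2 gives 400 nM, which is the highest of the two numbers recorded; the only step so far, a 6.5-fold higher number from compound 1 to compound 2 (0.81 log units; beyond the scatter), is the one by which compound 1 and compound 2 differ. Compound 3 `N#Cc1cccc(-n2nc(-c3ccccc3)cc2NC(=O)c2ccccc2)c1` has not been measured. It differs from compound 2 by cyano in place of bromo on an aromatic carbon, that is, 3-bromophenyl to 3-cyanophenyl, the new group sitting meta to a large group. Among the measured compounds shown here, no measured step bears on this exchange: the one known step, a 6.5-fold higher number from compound 1 to compound 2 (0.81 log units; beyond the scatter), alters both the halogen and its position at once and tells nothing about bromo against cyano at the same place. With no guidance from the data, compound 3 is expected to stay close to compound 2, the step of no change at the digits printed from compound 2 to compound 3 (within the scatter) being an estimate of no change beyond the scatter. Compound 3 is therefore estimated at 400 nM in this assay, within 150 nM to 1200 nM.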

Compound 3, half-maximal effective concentration: 117 nM
For compound 3 the middle estimate is 3.4-fold (0.53 log units) above the measured one, and the stated range ends above it.
By their numbers in this assay, from the lowest: compounds 1 and 3 (each within the scatter of the next); then compound 2.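

In this assay, the exchange at this place, meta to a large group, is not neutral: cyano in place of bromo gives a 3.4-fold lower number from compound 2 to compound 3 (0.53 log units; beyond the scatter), which shows that the number depends on the group at this position and not only on where the group stands. The other new step, a 1.9-fold higher number from compound 1 to compound 3 (0.28 log units; within the scatter), lies within the scatter, so 3-cyanophenyl and 2-chlorophenyl on the aromatic nitrogen cannot be told apart in this read-out. No measurement at hand accounts for the gap between bromo and cyano.

As far as these compounds go, whether an amine, a carboxylic acid or a methoxy group at this place would give numbers nearer to those of cyano or bromo remains open. The rest of the shared core stays the same throughout, so these compounds show nothing about changes elsewhere in it.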